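Benzyl for Phenyl on the Nitrone Nitrogen

A few compounds are considered here, and "the series" means these few. Any claim that something is new, unique, unknown or untested is made for them only; others in the source may bear on it.

Compound 1 `CCCCCCCCCCn1cc(/C=[N+](\[O-])c2ccccc2)nn1` is the starting point. In a functional assay on A549 cells (Homo sapiens) for inhibition, read by MTT assay, with a stated time of 24 h (on this read-out lower numbers stand for stronger inhibition and higher numbers for weaker inhibition), compound 1 gives > 100000 nM, which is a limit of the assay rather than a number. Compound 2 `[O-]/[N+](=C\c1cn(-c2ccccc2)nn1)Cc1ccccc1` gives > 100000 nM in this assay, likewise a limit. Compound 3 `COc1ccc(-n2cc(/C=[N+](\[O-])Cc3ccccc3)nn2)cc1` gives > 100000 nM, also a limit. The step that the two limits leave unreadable from compound 2 to compound 3 therefore cannot be read. Compound 4 `CCCCCCCCCCn1cc(/C=[N+](\[O-])Cc2ccccc2)nn1` differs from compound 1 by benzyl in place of phenyl on a double-bonded nitrogen. For the measured compounds named here, no measured step follows this exact change, but compound 2 and compound 3 already carry a benzyl at that nitrogen and both sit at the same limit, so no shift can be argued for; because the limit of > 100000 nM in this assay, at which 3 of the 3 values shown sit, holds every value shown, the expected step that the limit leaves unreadable from compound 1 to compound 4 is none. Compound 4 is therefore expected to give 200000 nM in this assay, within 100000 nM to 1000000 nM, most likely again as a limit.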

Compound 4, half-maximal inhibitory concentration: > 100000 nM
Compound 4 was reported as a limit; the forecaster's own chance of this, stated with the estimate: 85%; the middle value is on the limit's open side.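

Compound 1 and compound 4 are both reported only as limits, and no step can be read between them. The compounds shown leave open which change, if any, would give a measurable value for inhibition.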